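Heteroaryl swap at the sulfur-bound chain carbon

The compounds below may be only part of what the source reports. "The series", "measured", "known", "first", "only" and "open" are said of these compounds alone.

Measured so far:
compound 1 `N#Cc1c(N)nc(SCc2ncn[nH]2)c(C#N)c1-c1ccc(OCC2CC2)cc1`, 338 nM
compound 2 `CCOc1ccc(-c2c(C#N)c(N)nc(SCc3ncc[nH]3)c2C#N)cc1`, 8.2 nM
compound 3 `N#Cc1c(N)nc(SCc2cccnc2)c(C#N)c1-c1ccc(OCC2CC2)cc1`, 67 nM

All values come from an assay on CHO cells for displacement of a labelled ligand from adenosine receptor A1 (Homo sapiens), read by scintillation counting, with a stated time of 90 min; a lower number here means a stronger inhibitor, a higher number a weaker inhibitor. Compound 3 stands second highest of the three numbers; its nearest neighbour is compound 1, while compound 2 gives the lowest number of the set. Compound 4 `N#Cc1c(N)nc(SCc2csc(N)n2)c(C#N)c1-c1ccc(OCC2CC2)cc1` differs from compound 3 by 2-amino-1,3-thiazol-4-yl in place of pyridin-3-yl on a saturated chain carbon bound to a sulfur. Going by the values given here, the one measured step that bears on this place is a 5.0-fold lower number from compound 1 to compound 3 (0.70 log units; beyond the scatter), where a five-membered aromatic ring gave way to pyridin-3-yl. The change to compound 4 runs the other way, back to a five-membered aromatic ring, now carrying a hydrogen-bond donor; a modest step in the same direction as that reversal is expected, a 2.2-fold higher number from compound 3 to compound 4 (0.35 log units; beyond the scatter). Compound 4 is therefore estimated at 150 nM, with a range of 60 nM to 400 nM.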

Compound 4, inhibition constant: 140 nM
The estimate for compound 4 lay 1.1-fold (0.03 log units) above the measured number; the range from low to high includes it.
By their numbers in this assay, from the lowest: compound 2; then compound 3; then compound 4; then compound 1.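

Two five-membered aromatic rings on a saturated chain carbon bound to a sulfur give different numbers: 2-amino-1,3-thiazol-4-yl in place of 1H-1,2,4-triazol-5-yl gives (a 2.4-fold lower number from compound 1 to compound 4 (0.38 log units; beyond the scatter)), so ring size alone does not set the value here. Against pyridin-3-yl, the same group gives (a 2.1-fold higher number from compound 3 to compound 4 (0.32 log units; beyond the scatter)), leaving pyridin-3-yl with the lowest number among the three compounds that differ only here. Nothing available explains these steps.

Open, as far as these compounds go, is whether the amine on the thiazole contributes to the number of compound 4. Comparison with the unsubstituted 1,3-thiazol-4-yl would separate the amine from the ring.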